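The compounds below may be only part of what the source reports. "The series", "measured", "known", "first", "only" and "open" are said of these compounds alone.

Compound 3 `CCc1cccc(NC(=O)CN2CCN(c3ccc(Cl)cn3)CC2)c1` is one of three compounds of a shared core tested in an assay on HEK293 cells for displacement of a labelled ligand from D(4) dopamine receptor (Homo sapiens), read by scintillation counting, with a stated time of 60 min (a higher number here means a weaker inhibitor, a lower number a stronger inhibitor), where compound 3 gives 172 nM. Going by the values given here, its nearest neighbour is compound 2 `Cc1cccc(NC(=O)CN2CCN(c3ccc(Cl)cn3)CC2)c1`, which in this assay gives 95 nM; the step of a 1.8-fold higher number from compound 2 to compound 3 (0.26 log units; within the scatter) is the only single-point change measured here and lies within the scatter. Compound 1 `O=C(CN1CCN(c2ccccn2)CC1)Nc1cccnc1`, which carries an unsubstituted pyridine on the piperazine and a pyridin-3-yl on the amide nitrogen, gives 6410 nM, far weaker than compounds 2 and 3.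

Compound 4 `O=C(CN1CCN(c2ccc(Cl)cn2)CC1)Nc1cccnc1` is not yet measured. It differs from compound 3 in one place: pyridin-3-yl in place of 3-ethylphenyl on an amide-type nitrogen. Among the compounds with values here, no measured step addresses this kind of exchange on the amide nitrogen; the only measured step, from compound 2 to compound 3, concerns a saturated chain carbon and is within the scatter. Within the data shown here, the one compound that shares the pyridin-3-yl amide, compound 1, stands far below compounds 2 and 3 in this assay, although it also lacks the chlorine on the pyridine, so its value cannot be attributed to the amide group alone. On this basis a step of an 8.7-fold higher number from compound 3 to compound 4 (0.94 log units; beyond the scatter) toward a higher number is expected in this assay, and compound 4 is estimated at 1500 nM, with a range from 400 nM to 6000 nM.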

Compound 4, inhibition constant: 5000 nM
Compound 4: middle estimate off by 3.3-fold (0.52 log units), on the low side; low and high end bracket the measured number.
By their numbers in this assay, from the lowest: compounds 2 and 3 (each within the scatter of the next); then compounds 4 and 1 (each within the scatter of the next).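

In this assay, the exchange on the amide-type nitrogen now has a measured size: pyridin-3-yl in place of 3-ethylphenyl gives a 29-fold higher number from compound 3 to compound 4 (1.46 log units; beyond the scatter) and pyridin-3-yl in place of 3-methylphenyl gives a 53-fold higher number from compound 2 to compound 4 (1.72 log units; beyond the scatter) as a second large step in the same direction. With pyridin-3-yl held on that nitrogen, chloro in place of hydrogen on an aromatic carbon gives a 1.3-fold lower number from compound 1 to compound 4 (0.11 log units; within the scatter) and so makes no readable difference, which separates the two changes that compound 1 carried together and leaves the large steps with the exchange on the amide-type nitrogen. The compounds come with no evidence that would explain the size of this exchange.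

Going by these compounds, it remains open whether the large steps follow the ring nitrogen of pyridin-3-yl or the absence of a methyl or ethyl group on the ring, a question that an unsubstituted phenyl on the amide-type nitrogen would separate. Also open, on these data alone, is whether pyridin-2-yl, pyridin-4-yl or a pyridin-3-yl bearing an ethyl group would stand with compound 3 or with compound 4.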